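Adding methyl to the nitrogen chain of compound 3

A few compounds are considered here, and "the series" means these few. Any claim that something is new, unique, unknown or untested is made for them only; others in the source may bear on it.

In an ADME assay for lipophilicity (on this read-out lower numbers stand for lower lipophilicity and higher numbers for higher lipophilicity), compound 1 `COCc1cc(=O)c(O)co1` gives -0.62 and compound 2 `CCCOCc1cc(=O)c(O)co1` gives 0.3 while compound 3 `CCn1cccc(O)c1=O` gives 0.2 and so stands within the scatter of compound 2 and beyond the scatter of compound 1. Compound 4 `CCCn1cccc(O)c1=O` differs from compound 3 by one change (methyl in place of hydrogen on a saturated chain carbon, two bonds along the chain from an aromatic nitrogen), methyl in place of hydrogen on a saturated chain carbon, two bonds along the chain from an aromatic nitrogen. Within the data shown here, only one measured step bears on it, on a different core, namely a number 0.92 log units higher from compound 1 to compound 2 (beyond the scatter) with ethyl entering on a saturated chain carbon. Methyl being the smaller group, a smaller rise is expected in this assay of an estimated a number 0.45 log units higher from compound 3 to compound 4 (beyond the scatter) (upward, beyond the scatter only narrowly). Compound 4 is therefore estimated at 0.65 (range 0.4 to 0.95).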

Compound 4, distribution coefficient: 0.69
Compound 4: the middle estimate sits 0.04 log units below what was measured; the range from low to high includes it.
By their numbers in this assay, from the lowest: compound 1; then compounds 3 and 2 (each within the scatter of the next); then compound 4.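

In this assay, among these compounds, the added methyl, on a saturated chain carbon two bonds along the chain from an aromatic nitrogen, gives a number 0.49 log units higher from compound 3 to compound 4 (beyond the scatter) and so supplies the first measured step on the core of compound 3. A single added group on a saturated chain carbon has now moved the number upward on both cores shown. Nothing available explains the size of this rise. On these data alone, whether a longer chain such as butyl would raise the number further remains open, as does what an amine or a carboxylic acid in place of the propyl chain of compound 4 would give.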